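From 3-chlorobenzyl to 3-methylbenzyl: working notes

The source may hold more compounds than are shown below. What is called first, only, known or untested is meant among the compounds shown, and "the series" means these compounds.

compound 1 `COc1cc2[nH]nc(Cc3cccc(C)c3)c2cc1C(=O)N(C)Cc1ccccc1` gives "not determined" (no result reported)
compound 2 `CN(Cc1ccccc1)C(=O)c1cc2c(Cc3cccc(Cl)c3)n[nH]c2cc1O` gives 410 nM

Among the measured compounds shown here, in a functional assay on A2780 cells (Homo sapiens) for antiproliferative activity, read by resazurin assay, with a stated time of 72 h (a lower number here means a stronger inhibitor, a higher number a weaker inhibitor), compound 2 gives 410 nM and holds the only number so far. Compound 3 `Cc1cccc(Cc2n[nH]c3cc(O)c(C(=O)N(C)Cc4ccccc4)cc23)c1` is still unmeasured. Its change from compound 2 reads methyl in place of chloro on an aromatic carbon and puts methyl in place of chloro on an aromatic carbon, meta to a large group. For the measured compounds named here, no measured step bears on this change, so no shift beyond the scatter is expected in this assay and no direction is favoured. The expected step is a 1.2-fold higher number from compound 2 to compound 3 (0.09 log units; within the scatter) and remains an estimate. The estimate for compound 3 is 500 nM (expected range 200 nM to 1300 nM).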

Compound 3, half-maximal inhibitory concentration: 490 nM
Compound 3: middle estimate off by 1.0-fold (0.01 log units), on the high side; measured number inside the range.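

In this assay methyl in place of chloro gives a 1.2-fold higher number from compound 2 to compound 3 (0.08 log units; within the scatter) and so, at this position meta to a large group, 3-chlorobenzyl and 3-methylbenzyl are not separated beyond the scatter. Among the compounds shown here, this is the first readable step, and it rests on one pair of compounds. No available evidence accounts for this result.

On these data alone, how an amine, a carboxylic acid or a longer chain at this position would read stays open. As far as these compounds go, the methoxy group of compound 1 also remains open, since its step to compound 3 cannot be read.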